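Swapping a Hydroxymethyl for a Methylsulfamoyl on Compound 1

The source may report more compounds than this note shows. Statements on the series, on what has been measured and on what is new or still open speak of the compounds shown alone.

Compound 1, `OCc1ccc(-c2ccc3c(O)cccc3c2)cc1`: 14%
Compound 2, `COc1ccncc1-c1ccc2c(O)cccc2c1`: < 10%
Compound 3, `Oc1cccc2cc(-c3ccoc3)ccc12`: < 10%

In an assay for binding affinity to 17-beta-hydroxysteroid dehydrogenase type 1 (Homo sapiens), with a stated time of 20 min, tested at 1 uM (a higher number here means more inhibition at the concentration tested (going by the name of the read-out), a lower number less inhibition), compound 1 gives 14%. Compound 2 does not reach a number and sits at the limit of the assay, < 10%. Compound 3 also sits at that limit, < 10%. For the measured compounds named here, compound 1 therefore stands alone as the only compound with an actual reading; the other two are limits, as the limit of < 10% in this assay, at which 2 of the 3 values shown sit, shows. All three share the same core and differ only in the aryl group attached to it.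

Compound 4, `CNS(=O)(=O)c1ccc(-c2ccc3c(O)cccc3c2)cc1`, is not yet measured. It differs from compound 1 in one place: methylsulfamoyl in place of hydroxymethyl on an aromatic carbon. Going by the values given here, no measured pair in this set changes a group in that same way, so there is no direct guide to the size of the step in this assay. Given the low number of compound 1 in this assay, 14%, the step is expected to be small, within the usual scatter or only just beyond it, in either direction. Compound 4 is expected to give about 16%, between 5% and 32%. That means an expected step of a number 2 percentage points higher from compound 1 to compound 4 (within the scatter).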

Compound 4, a percentage reported as inhibition, at one concentration (the size of the read-out at that concentration, not a potency): 12%
For compound 4 the middle estimate is 4 percentage points above the measured one; low and high end bracket the measured number.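

For the compounds shown here, this is the first comparison in the set that changes only one place, and it gives a direct reading for this position in this assay. Replacing hydroxymethyl, with 2 heavy atoms, by methylsulfamoyl, with 5 heavy atoms, on the aromatic carbon para to a large group gives a number 2 percentage points lower from compound 1 to compound 4 (within the scatter), so this change leaves the reading where it was, despite the added atoms and the extra hydrogen-bond acceptor. Compound 1 and compound 4 both give weak readings, so the comparison is made close to the floor of what this assay reports: the limit of < 10% in this assay, at which 2 of the 4 values shown sit.

The compounds shown leave open whether another group at this position, such as an amine or a carboxylic acid, would move the reading beyond the scatter. From the compounds shown here alone, it also remains open whether a longer chain there would do so.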